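Dropping the amino group from a dichlorobenzimidazole

The source may hold more compounds than are shown below. What is called first, only, known or untested is meant among the compounds shown, and "the series" means these compounds.

Within the data shown here, the series is built on a shared core carrying a substituted benzimidazole-linked phenyl group, and the three measured members were assessed in an ADME assay on MT4 cells (Homo sapiens) for cytotoxicity, read by MTT assay, with a stated time of 96 h; on this read-out higher numbers stand for lower toxicity in this test and lower numbers for higher toxicity in this test. Compound 1 `COc1ccc(-c2nc3cc(Cl)c(Cl)cc3[nH]2)c(N)c1` gives 3000 nM in this assay, the lowest of the three numbers and therefore the most cytotoxic in this test. Compound 3 `O=C(CN1CCCC1)Nc1ccc(-c2nc3cc(C(F)(F)F)ccc3[nH]2)cc1` gives 18000 nM, which is a step beyond the scatter. Compound 2 `Fc1cccc(F)c1-c1nc2cc(C(F)(F)F)ccc2[nH]1` gives 100000 nM, further still from compound 1. Both of these carry a trifluoromethyl group instead of the two chlorines of compound 1, so no single change links them to it.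

Compound 4 `COc1ccc(-c2nc3cc(Cl)c(Cl)cc3[nH]2)cc1` keeps everything of compound 1 except one group: hydrogen in place of amino on an aromatic carbon. Among the measured compounds shown here, no measured pair with a matching change exists, so the direction of the step in this assay is uncertain, and a shift of modest size in either direction would be consistent with what is known. A small rise in the number for compound 4 is expected, with the step from compound 1 to compound 4 estimated at a 2.0-fold higher number from compound 1 to compound 4 (0.30 log units; within the scatter). Compound 4 is expected to give about 6000 nM, with a range from 1500 nM to 30000 nM.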

Compound 4, half-maximal cytotoxic concentration: 1000 nM
Compound 4: middle estimate off by 6.0-fold (0.78 log units), on the high side, and the stated range ends above it.
By their numbers in this assay, from the lowest: compound 4; then compound 1; then compound 3; then compound 2.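

In this assay, among these compounds, the change of amino to hydrogen gives a 3.0-fold lower number from compound 1 to compound 4 (0.48 log units; beyond the scatter) and so provides the first step that can be read at a single place. On an aromatic carbon ortho to a large group and meta to a methoxy group, the amino group is therefore not required for the cytotoxicity seen in this test, and its loss moves the number toward higher toxicity. No measurement shown here explains why the number falls when this group leaves.

Going by these compounds, whether a hydroxyl, a methyl or a dimethylamino group on this same carbon would shift the number in the same direction remains open. On these data alone, it is also open whether the loss of amino would have a similar effect with trifluoromethyl on the core in place of the two chlorines.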